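Swapping the Naphthalenesulfonyl Group for a Benzodioxin

A few compounds are considered here, and "the series" means these few. Any claim that something is new, unique, unknown or untested is made for them only; others in the source may bear on it.

Compound 1 `COc1ccc(S(=O)(=O)N2CC(C(=O)N(C)C3CCN(C)CC3)c3ccccc32)c2ccccc12` gives 7.94 nM in a functional assay on CHO cells for antagonist activity at 5-hydroxytryptamine receptor 6 (Homo sapiens), read by FLIPR; a lower number here means a stronger inhibitor, a higher number a weaker inhibitor.
Compound 2 `COc1ccc(S(=O)(=O)N2CC(C(=O)NC3CCN(Cc4ccccc4)CC3)c3ccccc32)c2ccccc12` gives 50.1 nM in this assay.
Compound 3 `CN1CCC(N(C)C(=O)C2CN(S(=O)(=O)c3cccc4ccccc34)c3ccccc32)CC1` gives 31.6 nM in this assay.

Of these three numbers, compound 3 holds the second highest. Its distance from compound 1 lies beyond the scatter, a 4.0-fold higher number from compound 1 to compound 3 (0.60 log units; beyond the scatter), whereas its value and that of compound 2 sit within the scatter of each other, so no order between those two can be read. Among the measured compounds shown here, compound 2 differs from the others in more than one place and gives no single step.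

Compound 4 `CN1CCC(N(C)C(=O)C2CN(S(=O)(=O)c3ccc4c(c3)OCCO4)c3ccccc32)CC1` carries 2,3-dihydro-1,4-benzodioxin-6-yl in place of naphthalen-1-yl on a sulfonyl sulfur. For the measured compounds named here, only one measured step bears on this aryl group on the sulfonyl sulfur, and that is a 4.0-fold higher number from compound 1 to compound 3 (0.60 log units; beyond the scatter), a modest change. That step swaps a single methoxy for hydrogen on the same ring system. Going by the values given here, the present change is larger in kind, exchanging the whole bicyclic aryl for a different one, and no measured pair shows its direction. A step of at least the size already seen, more likely toward a higher number, is therefore the expectation for this assay, written as a 2.0-fold higher number from compound 3 to compound 4 (0.30 log units; within the scatter), with wide uncertainty. Compound 4 is estimated at 63 nM, with a range from 15 nM to 250 nM.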

Compound 4, inhibition constant: 50.1 nM
The estimate for compound 4 lay 1.3-fold (0.10 log units) above the measured number, within the range that was stated.
By their numbers in this assay, from the lowest: compound 1; then compounds 3, 2 and 4 (each within the scatter of the next).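

In this assay, the exchange of the whole aryl group on the sulfonyl sulfur gave a 1.6-fold higher number from compound 3 to compound 4 (0.20 log units; within the scatter), so no order can be read between these two compounds, even though 2,3-dihydro-1,4-benzodioxin-6-yl brings a non-aromatic ring with 2 hetero atoms and 2 hydrogen-bond acceptors where naphthalen-1-yl had a second aromatic ring and none. Among the compounds shown here, until now, the only reading at this position was a 4.0-fold higher number from compound 1 to compound 3 (0.60 log units; beyond the scatter), a methoxy-for-hydrogen difference on the naphthalene that lies beyond the scatter; the new pair shows that a far larger change in atoms at the same place need not move the number beyond the scatter. Nothing available accounts for either outcome, so the result stands as an observation about these compounds alone.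

Still open, from the compounds shown here alone, is whether a methoxy group on an aromatic carbon of the 2,3-dihydro-1,4-benzodioxin-6-yl group would give a step like the one seen on the naphthalene. Equally open, going by these compounds, is how a single-ring aryl on the sulfonyl sulfur, such as plain phenyl or a phenyl carrying a dimethylamino group, would read in this assay.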